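This account rests on a few compounds, and the source may have more. Where it says the series, first, only, none or still open, it means among the compounds named here.

Compound 1 `CCCCOc1ccc(-c2nc3ncccn3c2N2C(=O)c3cccc(O)c3C2=O)cc1` — limit of the assay: > 100000 nM
Compound 2 `Nc1nc2ncccn2c1-c1ccc(Br)cc1` — limit of the assay: > 100000 nM
Compound 3 `O=C(O)CCCOc1ccc(-c2nc3ncccn3c2NC2CCCCC2)cc1` — limit of the assay: > 100000 nM

All three compounds were tested in a toxicity assay on A549 cells (Homo sapiens) for cytotoxicity, read by luminescence and CellTiter-Glo, with a stated time of 48 h; a lower number here means that less compound is tolerated, a higher number that more compound is tolerated. For compound 3 the result is a limit of the assay and not a number: within the range tested, the cells tolerated it. Among the compounds with values here, the same holds for the other two compounds, so that (the limit of > 100000 nM in this assay, at which 3 of the 3 values shown sit); no compound here has yet given a measured concentration at which half the cells die, and no difference between any two of them can be read from these values.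

The next compound, compound 4 `c1ccc(-c2nc3ncccn3c2NC2CCCCC2)cc1`, shares the core of compound 3 and differs from it in one place: hydrogen in place of 3-carboxypropoxy on an aromatic carbon. Within the data shown here, the change removes the only charged-at-neutral-pH group of compound 3 and leaves a smaller, neutral molecule.

Nothing among the three measured compounds points to a change in tolerance from such a step, since none of them reached a measurable toxic concentration. The expected step of a number no higher from compound 3 to compound 4 (the limit leaves the size open) from compound 3 to compound 4 is therefore none beyond the scatter. For compound 4 the estimate in this assay is 100000 nM, with a range from 30000 nM to 300000 nM, and most likely another limit.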

Compound 4, half-maximal cytotoxic concentration: 100000 nM
Compound 4: the middle estimate sits on the measured number at the digits printed; the measured number falls inside the stated range.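

In this assay compound 4 gives 100000 nM, the first result in this set that is printed as a plain number. Compound 3 gives > 100000 nM, which is a limit of the assay. Taking away the 3-carboxypropoxy group, which sits on a six-membered aromatic ring of carbon only, para to a large group, and leaving hydrogen there gives a number no higher from compound 3 to compound 4 (the limit leaves the size open), so this position can carry either the chain or hydrogen without the result moving far from the top of the tested range, though the true size of the step cannot be read and most of the set still offers no number for comparison: the limit of > 100000 nM in this assay, at which 3 of the 4 values shown sit.

The compounds shown leave open whether the chain itself matters, or only its carboxylic acid end, since a single step from a limit cannot separate the two. They also leave open what a methoxy group, a fluorine atom or a chain ending in an amine on that same aromatic carbon would give in this assay, and whether any of these would bring the value down to a clearly lower number.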